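The source may hold more compounds than are shown below. What is called first, only, known or untested is meant among the compounds shown, and "the series" means these compounds.

Compound 1 `CC(C)[C@@H](NC(=O)/C=C/c1ccncc1-c1ccc2ccccc2c1)C(=O)O`: "not determined" (no result reported)
Compound 2 `COC1CN(C(=O)/C=C/c2ccncc2-c2ccc3ccccc3c2)C1`: > 30000 nM
Compound 3 `O=C(/C=C/c1ccncc1-c1ccc2[nH]ccc2c1)N1CCOCC1`: "not determined" (no result reported)

Three compounds of the shared core have been looked at in a functional assay on HCT-116 cells (Homo sapiens) for inhibition, read by MTT assay, with a stated time of 72 h; a lower number here means a stronger inhibitor of growth, a higher number a weaker inhibitor of growth. For compound 1 the result reads "not determined" (no result reported), and for compound 3 it reads "not determined" (no result reported), so neither gives a number to compare against. Among the measured compounds shown here, compound 2 is the only one with a recorded value, and that value is a limit of the assay rather than a number: compound 2 gives > 30000 nM. For the measured compounds named here, compound 2 therefore stands at the limit of > 30000 nM in this assay, at which 1 of the 3 values shown sits, and no step between two measured compounds can be formed from these data.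

Compound 4 `CNC(=O)/C=C/c1ccncc1-c1ccc2ccccc2c1` has not yet been tested. It differs from compound 2 in one place: methylamino in place of 3-methoxyazetidin-1-yl on a carbonyl carbon. Going by the values given here, with no measured step to lean on, the size of the change cannot be read from the data; because compound 2 sits at the limit of > 30000 nM in this assay, at which 1 of the 3 values shown sits, the expected step is a number no higher from compound 2 to compound 4 (the limit leaves the size open), which is none beyond the scatter. Compound 4 is accordingly estimated at about 30000 nM, with a range from 8000 nM to 100000 nM, and most likely the assay would again report only a limit.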

Compound 4, concentration for 50% growth inhibition: 6550 nM
The estimate for compound 4 lay 4.6-fold (0.66 log units) above the measured number; the measured number lies below the stated range.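

The group on this carbonyl carbon proves able to move the result: methylamino in place of 3-methoxyazetidin-1-yl gives an at least 4.5-fold lower number from compound 2 to compound 4 (0.66 log units; beyond the scatter) in this assay. Compound 4 gives 6550 nM, so the shared core now has a measured number against which other groups at this place can be set. The entry for compound 2 is a limit, so the full size of the step stays open: the limit of > 30000 nM in this assay, at which 1 of the 4 values shown sits.

The change removes the four-membered ring and the methoxy group and brings in an amide hydrogen all at once, and the compounds shown do not separate these differences. On these data alone, whether dimethylamino, which carries no amide hydrogen, or a longer chain such as ethylamino would give a lower or higher number than methylamino also remains open.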